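A Trifluoromethyl Step on a Shared Core

The compounds below may be only part of what the source reports. "The series", "measured", "known", "first", "only" and "open" are said of these compounds alone.

Three compounds have been measured so far:

Compound 1 `c1ccc(COc2ccc(Nc3ncnc4cc5c(cc34)OCCOCCOCCO5)cc2)cc1` reaches only a limit of the assay, > 100000 nM.
Compound 2 `c1ccc(COc2ccccc2Nc2ncnc3cc4c(cc23)OCCOCCOCCO4)cc1` gives 37300 nM.
Compound 3 `FC(F)(F)c1ccc(COc2ccc(Nc3ncnc4cc5c(cc34)OCCOCCOCCO5)cc2)cc1` again reaches only a limit of the assay, > 100000 nM.

All three were tested in a functional assay on HepG2 cells (Homo sapiens) for antiproliferative activity, read by MTT assay, with a stated time of 72 h; on this read-out lower numbers stand for stronger inhibition and higher numbers for weaker inhibition. Two of the three values sit at the limit of > 100000 nM in this assay, at which 2 of the 3 values shown sit, so those two compounds give no number at all, only a limit. Within the data shown here, compound 2 is the one compound that gives a number.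

Compound 1 and compound 3 differ in one place: trifluoromethyl in place of hydrogen on an aromatic carbon. The step between them, a step that the two limits leave unreadable from compound 1 to compound 3, cannot be read, since both ends are limits. Compound 1 and compound 2 are built from the same atoms joined differently; the difference between their two cores is not broken down here.

Compound 4 `FC(F)(F)c1ccc(COc2ccccc2Nc2ncnc3cc4c(cc23)OCCOCCOCCO4)cc1` is still to be measured. Compared with compound 2 it carries the same change that turns compound 1 into compound 3: trifluoromethyl in place of hydrogen on an aromatic carbon. The place of the change is described in the same words in both pairs, so this is the same change.

Among the measured compounds shown here, since the only earlier example of this change gives no readable step, the expectation for compound 4 rests on compound 2 alone, whose value is 37300 nM, and the step from compound 2 to compound 4 is estimated to be small, a 1.3-fold higher number from compound 2 to compound 4 (0.13 log units; within the scatter). Compound 4 is therefore expected to come out near 50000 nM in this assay, somewhere between 15000 nM and 150000 nM, with a real chance that only a limit is reported.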

Compound 4, half-maximal inhibitory concentration: > 100000 nM
Compound 4 was reported as a limit; the forecaster's own chance of this, stated with the estimate: 35%; middle value at least 2.0-fold (0.30 log units) away from the limit.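

In this assay, trifluoromethyl in place of hydrogen on an aromatic carbon gives an at least 2.6-fold higher number from compound 2 to compound 4 (0.42 log units; beyond the scatter), so on the core of compound 2 the change clearly weakens inhibition. That step gives only a minimum size, because compound 4 reaches a limit of the assay and gives no number: the limit of > 100000 nM in this assay, at which 3 of the 4 values shown sit. Compound 1 and compound 3 are both limits as well, so the same change on their core cannot be read, and the series shows one readable example of the change rather than its carrying over from one core to another.

The compounds shown leave open how other groups would read in the same place on the benzyl ring, such as a methoxy group, an amine or a carboxylic acid in place of trifluoromethyl. They also leave open whether a longer chain in place of the benzyloxy group, such as phenylethoxy, would give a measurable number on either core, which could then allow a real comparison between the two.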